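The compounds below may be only part of what the source reports. "The series", "measured", "known", "first", "only" and "open" are said of these compounds alone.

Three compounds sharing one core and differing only in the amine-bearing chain have been measured in a functional assay on A549 cells (Homo sapiens) for cytotoxicity, read by MTT assay, with a stated time of 72 h; a higher number here means a weaker inhibitor, a lower number a stronger inhibitor. Compound 1 `CN1CCN(CCCCCn2c3c(c4ccccc42)C(=O)c2c[n+]([O-])c4ccccc4c2C3=O)CC1` gives 870 nM, compound 2 `O=C1c2c[n+]([O-])c3ccccc3c2C(=O)c2c1c1ccccc1n2CCCCN1CCNCC1` gives 540 nM, and compound 3 `CN(C)CCCCn1c2c(c3ccccc31)C(=O)c1c[n+]([O-])c3ccccc3c1C2=O` gives 310 nM. Compound 3 holds the lowest of the three numbers, yet a 1.7-fold lower number from compound 2 to compound 3 (0.24 log units; within the scatter) is within the scatter, so it cannot be called the strongest; only a 2.8-fold lower number from compound 1 to compound 3 (0.45 log units; beyond the scatter) clears the scatter, and that step is modest. Compound 4 `CN1CCN(CCCCn2c3c(c4ccccc42)C(=O)c2c[n+]([O-])c4ccccc4c2C3=O)CC1` differs from compound 3 in one place: 4-methylpiperazin-1-yl in place of dimethylamino on a saturated chain carbon, four bonds along the chain from an aromatic nitrogen. The step that bears most on this is a 2.8-fold lower number from compound 1 to compound 3 (0.45 log units; beyond the scatter), where a (4-methylpiperazin-1-yl)methyl group gave way to dimethylamino and the number fell modestly; a 1.7-fold lower number from compound 2 to compound 3 (0.24 log units; within the scatter), swapping piperazin-1-yl for dimethylamino, stayed within the scatter. Bringing the methylpiperazine ring back is therefore expected to raise the number modestly, an estimated 1.9-fold higher number from compound 3 to compound 4 (0.29 log units; within the scatter). Compound 4 is estimated to give 600 nM, with a likely range from 300 nM to 1200 nM.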

Compound 4, half-maximal inhibitory concentration: 90 nM
Beside the measured number, compound 4's estimate is 6.7-fold (0.82 log units) above it, outside the stated range (below it).
By their numbers in this assay, from the lowest: compound 4; then compounds 3, 2 and 1 (each within the scatter of the next, the first and the last beyond it).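

In this assay the 4-methylpiperazin-1-yl group, four bonds along the chain from an aromatic nitrogen, makes compound 4 the strongest of the set, and a 3.4-fold lower number from compound 3 to compound 4 (0.54 log units; beyond the scatter) shows that it outdoes dimethylamino at this place. Small edits to this group matter too: a 6.0-fold lower number from compound 2 to compound 4 (0.78 log units; beyond the scatter) follows from methyl in place of hydrogen on the ring amine nitrogen, while a 9.7-fold lower number from compound 1 to compound 4 (0.99 log units; beyond the scatter) follows from 4-methylpiperazin-1-yl in place of (4-methylpiperazin-1-yl)methyl, so the high number of compound 1 does not count against the ring itself. No supporting measurement is available to explain these differences.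

From the compounds shown here alone, whether a morpholine or piperidine ring at this place would match the methylpiperazine remains open. So does the effect of a larger group on the ring nitrogen, such as ethyl, or of a shorter chain.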